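Trimethoxyphenyl triazoles: fluoro for trifluoromethoxy

A few compounds are considered here, and "the series" means these few. Any claim that something is new, unique, unknown or untested is made for them only; others in the source may bear on it.

Compound 1 `COc1cc(-c2ncnn2-c2ccc([N+](=O)[O-])cc2)cc(OC)c1OC` in a functional assay on HeLa cells (Homo sapiens) for antiproliferative activity, read by MTT assay, with a stated time of 72 h (a lower number here means a stronger inhibitor, a higher number a weaker inhibitor), gives > 10000 nM, which is a limit of the assay and not a number.
Compound 2 `COc1cc(-c2ncnn2-c2ccc(N)cc2)cc(OC)c1OC` in this assay gives > 10000 nM, again a limit of the assay.
Compound 3 `COc1cc(-n2ncnc2-c2ccc(OC(F)(F)F)cc2)cc(OC)c1OC` in this assay gives > 10000 nM, also a limit of the assay.

Within the data shown here, compound 3 thus stands at the limit of this assay, where every value so far sits (the limit of > 10000 nM in this assay, at which 3 of the 3 values shown sit). No number is known for it, only that its inhibitory concentration lies beyond what the assay reports.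

Compound 4 `COc1cc(-n2ncnc2-c2ccc(F)cc2)cc(OC)c1OC` differs from compound 3 in one place: fluoro in place of trifluoromethoxy on an aromatic carbon. The trifluoromethoxy group leaves and fluoro enters on the same aromatic carbon of the six-membered ring of carbon only.

Among the measured compounds shown here, the one measured step, a step that the two limits leave unreadable from compound 1 to compound 2, is of unreadable size, since both of its end points are limits. For the measured compounds named here, no measured step therefore bears on the exchange from trifluoromethoxy to fluoro, and the three values give no anchor other than the limit itself (the limit of > 10000 nM in this assay, at which 3 of the 3 values shown sit). From this alone compound 4 is expected to remain at or near that limit, with the step that the limit leaves unreadable from compound 3 to compound 4 expected to be unreadable in the same way.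

Compound 4 is estimated at 15000 nM in this assay, with a range from 5000 nM to 50000 nM, most likely reported only as a limit.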

Compound 4, half-maximal inhibitory concentration: > 10000 nM
Compound 4: only a limit was reported (the forecaster's own chance of this, stated with the estimate: 80%); the middle value lies beyond the limit too.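

In this assay compound 4 gives > 10000 nM, a limit of the assay and not a number. Compound 3 also stands at a limit, so no step can be read between compound 3 and compound 4, and the series offers only one reference point: the limit of > 10000 nM in this assay, at which 4 of the 4 values shown sit. The compounds shown leave open which structural change, if any, would give a measurable inhibitory concentration.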